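A Methyl Group Added Para on Two Related Cores

A few compounds are considered here, and "the series" means these few. Any claim that something is new, unique, unknown or untested is made for them only; others in the source may bear on it.

Going by the values given here, compound 1 `O=C1NC(c2ccccc2)CN1S(=O)(=O)c1ccc2c(c1)CCC2` is the most potent of the three compounds measured so far. In a functional assay on SK-MEL-2 cells (Homo sapiens) for cytotoxicity (on this read-out lower numbers stand for stronger inhibition and higher numbers for weaker inhibition), compound 1 gives 2 nM. Compound 3 `O=C1NCC(c2ccccc2)N1S(=O)(=O)c1ccc2c(c1)CCC2` shares the same atoms as compound 1 but has them joined differently; the difference between the two cores is not broken down here. In this assay compound 3 gives 39000 nM, and compound 2 `Cc1ccc(C2CNC(=O)N2S(=O)(=O)c2ccc3c(c2)CCC3)cc1` gives 88600 nM.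

From compound 3 to compound 2 a single change is made (methyl in place of hydrogen on an aromatic carbon). That change produced a 2.3-fold higher number from compound 3 to compound 2 (0.36 log units; beyond the scatter).

Compound 4 `Cc1ccc(C2CN(S(=O)(=O)c3ccc4c(c3)CCC4)C(=O)N2)cc1` has not yet been measured. It differs from compound 1 by methyl in place of hydrogen on an aromatic carbon. The place lines for the two changes read the same word for word, so this is taken as the same change seen between compound 3 and compound 2, applied to the far more potent core of compound 1.

Among the compounds with values here, on this basis, the step from compound 1 to compound 4 is expected to be a modest weakening, a 3.0-fold higher number from compound 1 to compound 4 (0.48 log units; beyond the scatter), roughly in line with the step already seen from compound 3 to compound 2, with the caution that the earlier change sat on a weak core and only one such pair is available. For compound 4 the estimated value in this assay is 6 nM, with a range from 1.5 nM to 40 nM.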

Compound 4, half-maximal inhibitory concentration: 72500 nM
For compound 4 the middle estimate is 12000-fold (4.08 log units) below the measured one, outside the stated range (above it).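

In this assay, putting methyl in place of hydrogen on an aromatic carbon, which turns phenyl into 4-methylphenyl, gave a 36000-fold higher number from compound 1 to compound 4 (4.56 log units; beyond the scatter), a large loss on what had been the most potent core. The change moved the number in the same direction on both cores, but its size did not carry over from one core to the other: the same change on two cores in this assay, a 2.3-fold higher number (0.36 log units; beyond the scatter) from compound 3 to compound 2 and a 36000-fold higher number (4.56 log units; beyond the scatter) from compound 1 to compound 4, 16000-fold (4.20 log units) apart, beyond the scatter of two such steps. Going by these compounds alone, this shows that, in this series, the size of the step on one core cannot be taken as a guide to its size on the other, but with only one pair per core it does not show what sets the difference or how the change would behave on any further core.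

The compounds shown leave open whether the sharp loss on the core of compound 1 is specific to methyl or whether any group in that place would bring it, since a single fluorine or chlorine atom, a methoxy group or a longer chain such as ethyl does not appear among them. They also leave open whether the same group placed elsewhere on the phenyl ring would keep the low number of compound 1.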